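A Carboxy Group in a Series Held at Its Limit

A few compounds are considered here, and "the series" means these few. Any claim that something is new, unique, unknown or untested is made for them only; others in the source may bear on it.

Compound 1 (`Cc1ccc(NC(=O)Nc2cc(C)nc3ccccc23)cc1`) gives > 25000 nM in an ADME assay on HEK293 cells (Homo sapiens) for cytotoxicity, with a stated time of 72 h (on this read-out higher numbers stand for an effect only at larger amounts of compound and lower numbers for an effect already at smaller amounts), and that value is a limit, not a number. Compound 2 (`Cc1cc(NC(=O)Nc2ccc(N(C)C)cc2)c2ccccc2n1`) gives > 25000 nM in this assay and that value is also a limit. Compound 3 (`Cc1cc(NC(=O)Nc2ccc(O)cc2)c2ccccc2n1`) gives > 25000 nM in this assay and that value is a limit too, so compound 3 stands with no readable number of its own.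

Compound 4 (`Cc1cc(NC(=O)Nc2ccc(C(=O)O)cc2)c2ccccc2n1`) carries carboxy in place of hydroxy on an aromatic carbon. Three measured steps change the group at this same place: a step that the two limits leave unreadable from compound 1 to compound 2 and a step that the two limits leave unreadable from compound 1 to compound 3 and a step that the two limits leave unreadable from compound 2 to compound 3 give no size to build on. For compound 4, no step beyond the usual scatter is expected in this assay because the limit of > 25000 nM in this assay, at which 3 of the 3 values shown sit, covers compound 1, compound 2 and compound 3 alike, whichever group sits at that place. The expected change is a number no higher from compound 3 to compound 4 (the limit leaves the size open) and it remains only an estimate. Compound 4 is estimated at 25000 nM and a limit rather than a number is the likeliest report. The estimate for compound 4 runs from 12000 nM to 50000 nM as the expected range.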

Compound 4, half-maximal effective concentration: > 25000 nM
Compound 4: a limit, no number; the forecaster's own chance of this, stated with the estimate: 85%; the middle value lies on the limit itself.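

In this assay compound 4 gives > 25000 nM, and that value is a limit. The steps from compound 1, compound 2 and compound 3 to compound 4 cannot be read, because all four compounds share one limit: the limit of > 25000 nM in this assay, at which 4 of the 4 values shown sit. The compounds shown leave open whether the groups at this place differ at all in this read-out.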